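This account rests on a few compounds, and the source may have more. Where it says the series, first, only, none or still open, it means among the compounds named here.

Working notes on the series. Among the compounds with values here, in a functional assay on 786-0 cells (Homo sapiens) (a higher number here means a weaker inhibitor of growth, a lower number a stronger inhibitor of growth), compound 1 `Oc1cc(-c2ccc(Cl)cc2)nc2ncccc12` gives 33900 nM, the higher of the two numbers so far, and compound 2 `Cc1cnc2nc(-c3ccc(Cl)cc3)cc(O)c2c1` gives 6310 nM. Compound 3 `Cc1ccnc2nc(-c3ccc(Cl)cc3)cc(O)c12` has not yet been measured in this assay. Its change from compound 1 is methyl in place of hydrogen on an aromatic carbon, opposite the ring nitrogen.

Within the data shown here, only one measured step bears on this change: a 5.4-fold lower number from compound 1 to compound 2 (0.73 log units; beyond the scatter). It is modest, and it is the same kind of replacement made at a different carbon. A single step at another place is thin evidence, so it sets a direction more than a size. A lower number than that of compound 1 is therefore expected, but by less than the measured step, and a result within the scatter of compound 1 would not be surprising. The expected change is a 2.3-fold lower number from compound 1 to compound 3 (0.35 log units; beyond the scatter). For compound 3 the estimated value is 15000 nM, with an expected range of 5000 nM to 40000 nM.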

Compound 3, concentration for 50% growth inhibition: 3980 nM
Compound 3: middle estimate off by 3.8-fold (0.58 log units), on the high side, and the stated range ends above it.
By their numbers in this assay, from the lowest: compounds 3 and 2 (each within the scatter of the next); then compound 1.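

In this assay the step is an 8.5-fold lower number from compound 1 to compound 3 (0.93 log units; beyond the scatter) on methyl in place of hydrogen on an aromatic carbon, opposite the ring nitrogen, so the gain seen at one carbon of the shared core now also appears at a second carbon. Compound 2 gives 6310 nM and compound 3 gives 3980 nM, two values within the scatter of each other, so this assay does not separate the two placements of the methyl. Nothing at hand gives a measured reason for either step, and the numbers alone cannot say what the methyl does at this carbon.

Still open, from the compounds shown here alone, is whether the step at this carbon belongs to methyl alone or extends to an ethyl, a methoxy or a chlorine placed there. Also open, going by these compounds, is whether methyl groups at both carbons of the core would add their steps together or give no more than one methyl does.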